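This account rests on a few compounds, and the source may have more. Where it says the series, first, only, none or still open, it means among the compounds named here.

Of the compounds shown here, three of a shared core have been measured in an ADME assay on Vero cells (Chlorocebus sabaeus) for cytotoxicity; a lower number here means that less compound is tolerated, a higher number that more compound is tolerated. Compound 1, `NC(=O)c1cccc2[nH]c(-c3cccnc3)nc12`, gives 77.7 uM. Compound 2, `O=C(NCCO)c1cccc2[nH]c(-c3cccnc3)nc12`, gives 682 uM. Compound 3, `O=C(Nc1ccccc1F)c1cccc2[nH]c(-c3cccnc3)nc12`, gives 54.7 uM, the lowest of the three numbers; its nearest neighbour is compound 1 and its furthest is compound 2. The measured steps all concern the amide-type nitrogen: an 8.8-fold higher number from compound 1 to compound 2 (0.94 log units; beyond the scatter); a 1.4-fold lower number from compound 1 to compound 3 (0.15 log units; within the scatter); a 12-fold lower number from compound 2 to compound 3 (1.10 log units; beyond the scatter).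

Compound 4, `O=C(Nc1ccccc1F)c1cccc2[nH]c(-c3ccc([N+](=O)[O-])o3)nc12`, differs from compound 3 elsewhere: 5-nitrofuran-2-yl in place of pyridin-3-yl on an aromatic carbon. Among the measured compounds shown here, none of the measured steps touches this position, so no step in this assay gives a direct precedent for the change; the only guide is that the two aryl-type exchanges among the measured compounds shifted the numbers by modest to large amounts. Compound 4 is therefore expected to stay close to compound 3, with a wide range, as an estimated 1.4-fold lower number from compound 3 to compound 4 (0.14 log units; within the scatter). The estimated value for compound 4 in this assay is 40 uM, within 12 uM to 130 uM.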

Compound 4, half-maximal toxic concentration: 75.9 uM
Compound 4: middle estimate off by 1.9-fold (0.28 log units), on the low side, within the range that was stated.
By their numbers in this assay, from the lowest: compounds 3, 4 and 1 (each within the scatter of the next); then compound 2.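

In this assay, the exchange on the aromatic carbon between two ring nitrogen atoms gives a 1.4-fold higher number from compound 3 to compound 4 (0.14 log units; within the scatter) and is the only step shown at this position. With 2-fluorophenyl held on the amide-type nitrogen, a five-membered aromatic ring bearing a nitro group can thus stand in place of the six-membered pyridin-3-yl ring with no change beyond the scatter, whereas the amide-type nitrogen gave a 12-fold lower number from compound 2 to compound 3 (1.10 log units; beyond the scatter) in the same assay. No measurement at hand offers an explanation for this result.

Going by these compounds, it remains open whether a furan-2-yl group without the nitro group, an amine or a carboxylic acid at this position would move the number beyond the scatter. On these data alone, it is also open whether the same exchange would give a similar step with 2-hydroxyethyl on the amide-type nitrogen.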